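Pyrrole to chlorophenyl on a cyanoacrylamide core

The source may hold more compounds than are shown below. What is called first, only, known or untested is meant among the compounds shown, and "the series" means these compounds.

Going by the values given here, the account concerns compound 1, `N#C/C(=C\c1ccc[nH]1)C(=O)NCc1ccc(Cl)c(Cl)c1`, and the single measurement that exists for it. In a functional assay on DU-145 cells (Homo sapiens) for inhibition, read by MTT assay, with a stated time of 72 h (on this read-out lower numbers stand for stronger inhibition of growth and higher numbers for weaker inhibition of growth), compound 1 gives only a limit, > 50000 nM, and not a number. Where it stands is described by the limit of > 50000 nM in this assay, at which 1 of the 2 values shown sits. Among the compounds with values here, the other measured member of the set is compound 2, `COc1ccc(CNC(=O)/C(C#N)=C/c2ccc(C)cc2)cc1`, which in this assay gives 34000 nM; the two compounds differ in more than one place, so no step between them is counted, and their two values show only that both are weak.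

The unmeasured compound 3, `N#C/C(=C\c1ccc(Cl)cc1)C(=O)NCc1ccc(Cl)c(Cl)c1`, differs from compound 1 by one change: 4-chlorophenyl in place of 1H-pyrrol-2-yl on a double-bonded chain carbon bound to a double-bonded chain carbon.

With compound 1 known only as a limit, the step is expected to be small or none beyond the scatter, and the estimated step is an at least 1.4-fold lower number from compound 1 to compound 3 (0.15 log units; that floor lies within the scatter). Compound 3 is expected at about 35000 nM, with a range from 12000 nM to 100000 nM, because the aryl analogue compound 2 gives 34000 nM in this assay.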

Compound 3, concentration for 50% growth inhibition: 30000 nM
Compound 3: the middle estimate sits 1.2-fold (0.07 log units) above what was measured; the range from low to high includes it.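

Compound 1 stands in this assay only as a limit, > 50000 nM, and not as a number. Placing 4-chlorophenyl in place of 1H-pyrrol-2-yl on a double-bonded chain carbon bound to a double-bonded chain carbon gives an at least 1.6-fold lower number from compound 1 to compound 3 (0.22 log units; that floor lies within the scatter), which is the first step that can be read at this position, though only as a floor and with no shift beyond the scatter established. The change also takes away the one hydrogen-bond donor counted on the leaving group and leaves compound 3 with a measured value in the same weak range, yet the true size of the step stays unsettled, and what fixes this is the following: the limit of > 50000 nM in this assay, at which 1 of the 3 values shown sits.

The compounds shown do not separate the ring exchange from the chlorine that comes with it, and an unsubstituted phenyl group on the same carbon would be needed to tell the two apart. They also leave open how this position responds to a quite different group, such as a 4-aminophenyl or a 4-carboxyphenyl, on the shared core.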